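The source may hold more compounds than are shown below. What is called first, only, known or untested is meant among the compounds shown, and "the series" means these compounds.

Within the data shown here, compound 2 `Cc1c(F)c(Oc2cccc(OC(C)C)c2)nc(Oc2cccc(C(=N)N)c2)c1F` is the only member of this small set with a numeric result: in an assay on isolated protein for inhibition of serine protease 1 (Bos taurus) (on this read-out lower numbers stand for stronger inhibition and higher numbers for weaker inhibition), compound 2 gives 2900 nM. Compound 1 `Cc1c(F)c(Oc2cccc(C(=N)N)c2)nc(Oc2cccc(C(=O)O)c2)c1F` reaches only a limit of the assay, > 5000 nM. Among the measured compounds shown here, the single measured step, an at least 1.7-fold lower number from compound 1 to compound 2 (0.23 log units; that floor lies within the scatter), rests on that limit of > 5000 nM in this assay, at which 1 of the 2 values shown sits, and so sets no firm size. Compound 3 `Cc1c(Oc2nc(Oc3cccc(C(=N)N)c3)c(F)c(C)c2F)cccc1N(C)C` differs from compound 2 by 3-(dimethylamino)-2-methylphenyl in place of 3-isopropoxyphenyl on an oxygen on an aromatic ring. For the measured compounds named here, with no measured step touching such an exchange, compound 3 is expected to stay within scatter of compound 2, the estimated step being a 1.2-fold lower number from compound 2 to compound 3 (0.06 log units; within the scatter). For compound 3 the expected inhibition constant is 2500 nM, estimated between 800 nM and 8000 nM.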

Compound 3, inhibition constant: 5000 nM
Compound 3: middle estimate off by 2.0-fold (0.30 log units), on the low side; measured number inside the range.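

Placing 3-(dimethylamino)-2-methylphenyl in place of 3-isopropoxyphenyl on an oxygen on an aromatic ring gives a 1.7-fold higher number from compound 2 to compound 3 (0.24 log units; within the scatter) and this is the only step at the position with a readable size, and it does not separate the two groups. The other comparison gives a number no higher from compound 1 to compound 3 (the limit leaves the size open) and cannot be read as a size, since compound 1 stands at a limit: the limit of > 5000 nM in this assay, at which 1 of the 3 values shown sits.

The compounds shown leave open what the dimethylamino and methyl groups each contribute on their own. They also leave open whether a primary amine or a longer alkoxy chain on this ring would give a step beyond the scatter.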